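This account rests on a few compounds, and the source may have more. Where it says the series, first, only, none or still open, it means among the compounds named here.

Two compounds of this series carry numbers in a functional assay (brain) for displacement of a labelled ligand, with Rattus norvegicus as the target; a higher number here means a weaker inhibitor, a lower number a stronger inhibitor. Compound 1 `CC[C@]1(c2ccc(F)cc2)OC[C@H]([C@@H]2CCCCN2)O1` gives 649 nM. Compound 2 `CCN1CCCC[C@H]1[C@H]1COC(c2ccccc2)(c2ccccc2)O1` gives 6900 nM, the highest of the two numbers; the gap to compound 1 lies beyond the usual scatter. For the measured compounds named here, the two structures differ in more than one place, so only the two values themselves are recorded, with no single step drawn between them.

Compound 3 `c1ccc(CN2CCCC[C@H]2[C@H]2COC(c3ccccc3)(c3ccccc3)O2)cc1` remains to be measured in this assay. It differs from compound 2 in one place: phenyl in place of methyl on a saturated chain carbon bound to an amine nitrogen in a ring. The same difference, cut one bond further out, reads ethyl to benzyl. Going by the values given here, no measured pair in the set carries this change, so there is no step to lean on, and the expectation rests on compound 2 alone. A modest move toward a lower number is expected; the step estimated here, a 1.7-fold lower number from compound 2 to compound 3 (0.24 log units; within the scatter), may well stay within the scatter. Compound 3 is expected to give about 4000 nM in this assay, with a range from 1000 nM to 15000 nM.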

Compound 3, inhibition constant: 10100 nM
Estimate against measurement, compound 3: 2.5-fold (0.40 log units) below; the range from low to high includes it.
By their numbers in this assay, from the lowest: compound 1; then compounds 2 and 3 (each within the scatter of the next).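

In this assay, the place on a saturated chain carbon bound to an amine nitrogen in a ring now has its first readable step: phenyl in place of methyl, read further out as ethyl to benzyl, gives a 1.5-fold higher number from compound 2 to compound 3 (0.17 log units; within the scatter). Within this one pair, the added six-membered aromatic ring therefore leaves the number indistinguishable from that of the ethyl compound, and the change neither recovers nor loses anything measurable in this assay, so this single step shows no dependence on the size of the group at this place. No supporting measurement bears on this result, and the step stands without an explanation.

Compound 1 gives 649 nM but differs from compound 2 and compound 3 in more than one place. This step does not address its separate standing. Still open, on these data alone, is whether a longer chain such as propyl, a hydroxyl, an amine or a carboxylic acid at the same place, or a fluorine on the added phenyl, would move the number beyond the scatter.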